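The source may hold more compounds than are shown below. What is called first, only, known or untested is meant among the compounds shown, and "the series" means these compounds.

The measured compounds and their values:

Compound 1 `Cc1cc(O)c(C(=O)/C=C/c2ccc(Br)cc2)c(-c2ccc(OCc3ccccc3)cc2)c1C(=O)/C=C/c1ccc(Br)cc1`, which in a functional assay on MCF7 cells (Homo sapiens) for cytotoxicity, read by MTT assay, with a stated time of 24 h (a lower number here means a stronger inhibitor, a higher number a weaker inhibitor), gives 30000 nM.
Compound 2 `Cc1cc(O)c(C(=O)/C=C/c2ccc(Br)cc2)c(-c2ccccc2)c1C(=O)/C=C/c1ccc(Br)cc1`, which in this assay gives 10000 nM.

Compound 2 holds the lowest of the two numbers. Within the data shown here, its nearest neighbour is compound 1, and the only measured step between them runs from the benzyloxy-bearing compound to the unsubstituted one: a 3.0-fold lower number from compound 1 to compound 2 (0.48 log units; beyond the scatter), a change in one place on the pendant phenyl.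

Compound 3 `Cc1cc(O)c(C(=O)/C=C/c2ccc(Br)cc2)c(-c2ccc(Br)cc2)c1C(=O)/C=C/c1ccc(Br)cc1` differs from compound 2 by bromo in place of hydrogen on an aromatic carbon. Among the measured compounds shown here, the one step that bears on this position is the step from compound 1 to compound 2, where benzyloxy left the same carbon and the number fell by a modest amount. Bromo, however, is a single heavy atom, not the benzyloxy group whose removal produced that step, so the comparison is only loose. The expectation for compound 3 is therefore a step of no more than the usual scatter, with any lean going toward a somewhat higher number than compound 2.

The expected step is a 1.3-fold higher number from compound 2 to compound 3 (0.11 log units; within the scatter). Compound 3 is thus estimated at 13000 nM in this assay, with a range from 5000 nM to 35000 nM.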

Compound 3, half-maximal inhibitory concentration: 15000 nM
The estimate for compound 3 lay 1.2-fold (0.06 log units) below the measured number; low and high end bracket the measured number.
By their numbers in this assay, from the lowest: compounds 2, 3 and 1 (each within the scatter of the next, the first and the last beyond it).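

In this assay, the change from phenyl to 4-bromophenyl gives a 1.5-fold higher number from compound 2 to compound 3 (0.18 log units; within the scatter), so a single bromo on this aromatic carbon cannot be told apart from hydrogen. Bromo in place of benzyloxy on the same carbon gives a 2.0-fold lower number from compound 1 to compound 3 (0.30 log units; within the scatter), so compound 3 cannot be told apart from compound 1 either, although the hydrogen compound does stand apart from the benzyloxy compound, with a 3.0-fold lower number from compound 1 to compound 2 (0.48 log units; beyond the scatter) as the one step here beyond the scatter. No measurement shown here offers an explanation for these numbers.

The three compounds therefore give no firm ranking of bromo against the other two groups at this position, and all of them remain weak in the same range of numbers. Open, from the compounds shown here alone, is how a methoxy group, an amine or a carboxylic acid on this carbon would read in this assay, and whether replacing the bromo groups on the two side chains of the shared core with hydrogen or chloro would move the number further than anything seen at this position.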